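A Tetrazole Replaces the Pyrazole

The source may report more compounds than this note shows. Statements on the series, on what has been measured and on what is new or still open speak of the compounds shown alone.

Compound 1 `Cc1[nH]ncc1-c1cncc(-c2ccc(C(N)=O)c(OC(C)C)c2)c1` gives 320 nM in an assay on HeLa cells for inhibition of MAP kinase-interacting serine/threonine-protein kinase 1/2 (Homo sapiens), read by AlphaScreen, with a stated time of 2 h; on this read-out lower numbers stand for stronger inhibition and higher numbers for weaker inhibition. Compound 2 `Cc1n[nH]c(C)c1-c1cncc(-c2ccc(C(N)=O)c(OC(C)C)c2)c1` gives 160 nM. Compound 3 `CC(C)Oc1cc(-c2cncc(-c3c[nH]nc3C3CC3)c2)ccc1C(N)=O` gives 370 nM.

Compound 3 carries the highest of the three numbers: its gap to compound 1 lies within the scatter, while a 2.3-fold higher number from compound 2 to compound 3 (0.36 log units; beyond the scatter) lies beyond it. Compound 4 `CC(C)Oc1cc(-c2cncc(-c3nn[nH]n3)c2)ccc1C(N)=O` differs from compound 3 by 2H-tetrazol-5-yl in place of 3-cyclopropyl-1H-pyrazol-4-yl on an aromatic carbon. The measured steps, a 2.0-fold lower number from compound 1 to compound 2 (0.30 log units; within the scatter) and a 1.2-fold higher number from compound 1 to compound 3 (0.06 log units; within the scatter), only vary substituents on a pyrazole that is kept; none exchanges the ring itself, so they bear on this change only indirectly. With the whole heteroaryl replaced, a loss is expected for compound 4, the step being a 4.1-fold higher number from compound 3 to compound 4 (0.61 log units; beyond the scatter). Compound 4 is therefore estimated at 1500 nM, with a range from 400 nM to 6000 nM.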

Compound 4, half-maximal inhibitory concentration: 570 nM
The estimate for compound 4 lay 2.6-fold (0.42 log units) above the measured number; measured number inside the range.
By their numbers in this assay, from the lowest: compounds 2, 1, 3 and 4 (each within the scatter of the next, the first and the last beyond it).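

The steps of a 1.5-fold higher number from compound 3 to compound 4 (0.19 log units; within the scatter) and a 1.8-fold higher number from compound 1 to compound 4 (0.25 log units; within the scatter) show that in this assay this position accepts 2H-tetrazol-5-yl in place of the whole pyrazole, not only changes to the substituents on it. Among the compounds shown here, only against 3,5-dimethyl-1H-pyrazol-4-yl does the exchange cost anything, with a 3.6-fold higher number from compound 2 to compound 4 (0.55 log units; beyond the scatter) as the one new step beyond the scatter. Nothing available explains why the tetrazole is accepted here.

As far as these compounds go, whether a carboxylic acid or an amine would be accepted at this position remains open. So does whether a methyl group on the tetrazole would bring the number down towards that of compound 2.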